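Two Changes and a Predicted Cytotoxicity for Compound 4

The source may report more compounds than this note shows. Statements on the series, on what has been measured and on what is new or still open speak of the compounds shown alone.

Measured compounds:
Compound 1 `COc1ccc(C2=C(c3cc(OC)c(OC)c(OC)c3)C(=O)CC2O[SiH2]C(C)(C)C)cc1` in an ADME assay on PA-1 cells (Homo sapiens) for cytotoxicity, read by MTT assay, with a stated time of 72 h (a lower number here means a stronger inhibitor, a higher number a weaker inhibitor), gives only a limit, > 100 ug/mL.
Compound 2 `COc1ccc(OC)c(C2=C(c3cc(OC)c(OC)c(OC)c3)C(=O)CC2O[SiH2]C(C)(C)C)c1` gives 17 ug/mL.
Compound 3 `COc1ccc(C2=C(c3cc(OC)c(OC)c(OC)c3)C(=O)CC2O)cc1` gives 3.38 ug/mL.

The result for compound 1 is a limit of the assay, not a number. For that reason the step of an at least 29-fold lower number from compound 1 to compound 3 (1.47 log units; beyond the scatter) is known only as a bound; its change is a hydrogen atom in place of a group of 5 heavy atoms (4 carbon, 1 silicon; no ring), on an oxygen on a saturated carbon. The other measured step, an at least 5.8-fold lower number from compound 1 to compound 2 (0.76 log units; beyond the scatter), comes from 2,5-dimethoxyphenyl in place of 4-methoxyphenyl on a double-bonded ring carbon, and this is how the two cores differ. Compound 4 `COc1ccc(OC)c(C2=C(c3cc(OC)c(OC)c(OC)c3)C(=O)CC2O)c1` has not yet been measured in this assay. It differs from compound 2 by a hydrogen atom in place of a group of 5 heavy atoms (4 carbon, 1 silicon; no ring), on an oxygen on a saturated carbon, the same change that was made from compound 1 to compound 3, at the same place. Because the earlier instance of this change gave an at least 29-fold lower number from compound 1 to compound 3 (1.47 log units; beyond the scatter), a step of comparable direction is expected here, a 6.8-fold lower number from compound 2 to compound 4 (0.83 log units; beyond the scatter), starting from the value of compound 2. Compound 4 is therefore estimated at 2.5 ug/mL, with a likely range from 0.8 ug/mL to 8 ug/mL.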

Compound 4, half-maximal inhibitory concentration: > 100 ug/mL
Compound 4 was reported as a limit; the forecaster's own chance of this, stated with the estimate: 2%; middle value at least 40-fold (1.60 log units) from the limit.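

In this assay, a hydrogen atom in place of the silicon-containing group on the oxygen gives an at least 5.8-fold higher number from compound 2 to compound 4 (0.76 log units; beyond the scatter). This change therefore cannot be carried from one core to the other as a fixed step, since the number moves in opposite directions on the two cores: the same change on two cores in this assay, an at least 29-fold lower number (1.47 log units; beyond the scatter) from compound 1 to compound 3 and an at least 5.8-fold higher number (0.76 log units; beyond the scatter) from compound 2 to compound 4, at least 170-fold (2.24 log units) apart, beyond the scatter of two such steps Compound 4 gives > 100 ug/mL, which is a limit of the assay and not a number, so the data show the direction of the new step but neither its true size nor the reason the two cores part ways: the limit of > 100 ug/mL in this assay, at which 2 of the 4 values shown sit.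

The compounds shown hold only the silicon-containing group and the free hydroxyl group on that oxygen, so it remains open how a methyl ether, an acetate ester or an amine at the same place would behave on each core. As far as these compounds go, it is also open whether the reversal is tied to the 2,5-dimethoxyphenyl group or would appear with other groups on that ring.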